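Trimming a Dichlorophenyl Ester from a Long Thioether Chain

The source may hold more compounds than are shown below. What is called first, only, known or untested is meant among the compounds shown, and "the series" means these compounds.

Compound 1 `CCCOc1ccc(NC(=O)CSc2nnc(Cc3nn(C)c(=O)c4ccccc34)n2C)cc1`: > 30000 nM
Compound 2 `Cn1c(Cc2nn(C)c(=O)c3ccccc23)nnc1SCCCCCCCCCCC(=O)Oc1ccc(Cl)cc1Cl`: 8700 nM

Of the compounds shown here, two built on the same core have been tested in an assay on isolated protein (Mus musculus) for inhibition of IL15-IL15 receptor (Homo sapiens), read by resazurin assay, with stated times of 30 min and 2.5 days; on this read-out higher numbers stand for weaker inhibition and lower numbers for stronger inhibition. For compound 1 the result is only a limit of the assay, > 30000 nM (the limit of > 30000 nM in this assay, at which 1 of the 2 values shown sits). Within the data shown here, compound 2 gives 8700 nM in this assay, the only number among the two values shown. Compound 3 `CCCCCCCCCCSc1nnc(Cc2nn(C)c(=O)c3ccccc23)n1C` has not yet been measured. It differs from compound 2 by hydrogen in place of (2,4-dichlorophenoxy)carbonyl on a saturated chain carbon, ten or more bonds along the chain from a sulfur, so that only the saturated chain remains at that end of the molecule. Among the measured compounds shown here, no measured step of this kind is available, so the size of the change is uncertain; the most likely outcome is a small shift toward weaker inhibition, possibly within the scatter, estimated as a 1.7-fold higher number from compound 2 to compound 3 (0.24 log units; within the scatter). Compound 3 is therefore expected to show about 15000 nM in this assay, with a range from 5000 nM to 45000 nM.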

Compound 3, half-maximal inhibitory concentration: 7600 nM
For compound 3 the middle estimate is 2.0-fold (0.30 log units) above the measured one; measured number inside the range.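

In this assay, taking the (2,4-dichlorophenoxy)carbonyl off the saturated chain gives a 1.1-fold lower number from compound 2 to compound 3 (0.06 log units; within the scatter). This whole group, with its aromatic ring and both chlorine atoms, can therefore leave this end of the molecule without a change beyond the scatter, and the saturated chain alone gives a reading level with that of compound 2. Nothing measured here accounts for this result.

Going by these compounds, it remains open whether a different end group on the chain, such as a carboxylic acid or an amine, or a longer chain, would move the number beyond the scatter. Compound 1 gives only a limit of the assay, > 30000 nM, and differs from compound 3 in more than one place, so the part the chain itself plays also stays unresolved.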